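A hydroxy group on a chain at the assay limit

The source may report more compounds than this note shows. Statements on the series, on what has been measured and on what is new or still open speak of the compounds shown alone.

In a functional assay on HeLa cells (Homo sapiens) for cytotoxicity, read by MTT assay (a higher number here means a weaker inhibitor, a lower number a stronger inhibitor), compound 1 `CC(=O)C(C)CCCCc1cc(O)c(C)c(=O)o1` gives > 200000 nM, a limit of the assay and not a number. Compound 2 `CCC(C)CCCCc1cc(O)c(C)c(=O)o1` gives > 200000 nM, also a limit. Within the data shown here, the only measured step, a step that the two limits leave unreadable from compound 1 to compound 2, therefore has no readable size. Compound 3 `Cc1c(O)cc(CCCCC(C)[C@H](C)O)oc1=O` differs from compound 2 by hydroxy in place of hydrogen on a saturated chain carbon bound to two saturated chain carbons. Among the measured compounds shown here, the sole guide is the limit of > 200000 nM in this assay, at which 2 of the 2 values shown sit, so in this assay no step beyond the scatter is expected, in either direction, and another limit is the likeliest outcome. The expected step is a step that the limit leaves unreadable from compound 2 to compound 3. Compound 3 is estimated at 220000 nM, with an expected range from 100000 nM to 500000 nM.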

Compound 3, half-maximal inhibitory concentration: > 200000 nM
Compound 3: no number, only a limit (the forecaster's own chance of this, stated with the estimate: 85%); the middle value is on the limit's open side.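

Among these compounds, no step among compound 1, compound 2 and compound 3 can be read: all three give only a limit of the assay. The compounds shown leave open whether acetyl, ethyl or 1-hydroxyethyl on this chain makes any difference in this assay at all.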